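The source may report more compounds than this note shows. Statements on the series, on what has been measured and on what is new or still open speak of the compounds shown alone.

Three compounds share one core and differ only in the group on an amide-type nitrogen. Compound 1 `Cn1nc(COc2cc(F)cc(F)c2)c2c1CCN(C(=O)Nc1ccc(Cl)cc1)C2` carries a 4-chlorophenyl group there, and in an assay on cells for inhibition of Pendrin (Mus musculus), read by fluorescence, with a stated time of 10 min (on this read-out lower numbers stand for stronger inhibition and higher numbers for weaker inhibition), compound 1 gives 3100 nM. Compound 2 `Cn1nc(COc2cc(F)cc(F)c2)c2c1CCN(C(=O)Nc1ccc(Br)cc1)C2` carries a 4-bromophenyl group instead, and compound 2 gives 3300 nM; the step of a 1.1-fold higher number from compound 1 to compound 2 (0.03 log units; within the scatter) stays within the scatter. Compound 3 `Cn1nc(COc2cc(F)cc(F)c2)c2c1CCN(C(=O)NC1CCCCC1)C2` carries a cyclohexyl group on that nitrogen. For compound 3 this assay reports only a limit, > 10000 nM. Because of the limit of > 10000 nM in this assay, at which 1 of the 3 values shown sits, the steps of an at least 3.2-fold higher number from compound 1 to compound 3 (0.50 log units; beyond the scatter) and an at least 3.0-fold higher number from compound 2 to compound 3 (0.48 log units; beyond the scatter) are known only as lower bounds: the cyclohexyl group weakens inhibition by at least a modest amount. Compound 4 `Cn1nc(COc2cc(F)cc(F)c2)c2c1CCN(C(=O)NC(=O)c1ccccc1)C2` is not yet measured. It differs from compound 3 in one place: benzoyl in place of cyclohexyl on an amide-type nitrogen. Within the data shown here, both aromatic groups gave a measurable number where the cyclohexyl group gave a limit, but a benzoyl group has no measured counterpart here. The expected step of an at least 1.2-fold lower number from compound 3 to compound 4 (0.09 log units; that floor lies within the scatter) is therefore small or at most modest, toward stronger inhibition. Compound 4 is estimated at 8000 nM, within 2500 nM to 25000 nM.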

Compound 4, half-maximal inhibitory concentration: > 10000 nM
Compound 4 ended at the assay's limit; the forecaster's own chance of this, stated with the estimate: 45%; at least 1.2-fold (0.09 log units) between middle value and limit.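

Benzoyl in place of 4-chlorophenyl gives an at least 3.2-fold higher number from compound 1 to compound 4 (0.50 log units; beyond the scatter), and benzoyl in place of 4-bromophenyl gives an at least 3.0-fold higher number from compound 2 to compound 4 (0.48 log units; beyond the scatter); both steps are lower bounds, as the result for compound 4 is only a limit. Compound 4 carries a six-membered aromatic ring of carbon only, so an aromatic ring in the group on this nitrogen is not enough on its own to give a measurable number in this assay, which so far only the 4-chlorophenyl and 4-bromophenyl groups do. Compound 3 and compound 4 cannot be ranked against each other, and the step between them cannot be read, because both results are limits: the limit of > 10000 nM in this assay, at which 2 of the 4 values shown sit.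

Going by these compounds, whether the chlorine and bromine atoms matter, or only the ring that carries them, stays open. A plain phenyl group on this nitrogen would help to separate the two, and a 4-methoxyphenyl group would show whether other groups on that ring are tolerated.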